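The source may hold more compounds than are shown below. What is called first, only, known or untested is meant among the compounds shown, and "the series" means these compounds.

Of the compounds shown here, three have been measured in a functional assay on the whole organism (strain Wistar Albino) for inhibition, with Rattus norvegicus as the target, read by paw edema, with a stated time of 4 h, at a dose of 20 mg/kg; a higher number here means more inhibition at the dose given (going by the name of the read-out), a lower number less inhibition: compound 1 `COc1ccc(Cl)c(-c2nnc3sc(-c4ccnc(Cl)c4)nn23)c1` gives 27.2%, compound 2 `COc1ccc2[nH]c(C)c(Cc3nn4c(Cc5ccc(OC)c(OC)c5)nnc4s3)c2c1` gives 28.4%, and compound 3 `COc1ccc(Cl)c(-c2nnc3n2NC(c2ccco2)S3)c1` gives 25.6%. Compound 3 holds the lowest of the three numbers, but its gap to compound 1 and its gap to compound 2 both lie within the scatter, so no order among the three can be read from these numbers. Compound 4 `COc1ccc(Cl)c(-c2nnc3n2NC(c2cccn2C)S3)c1` differs from compound 3 by 1-methyl-1H-pyrrol-2-yl in place of furan-2-yl on a saturated ring carbon. Going by the values given here, no step between measured compounds is available to gauge a change of this kind, and the three numbers at hand sit close together. In this assay a step of a number 0.4 percentage points higher from compound 3 to compound 4 (within the scatter) is expected, within the scatter and with no direction preferred. Compound 4 is estimated at 26%, with a range from 18% to 34%.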

Compound 4, a percentage reported as inhibition, in the whole organism at one dose (the size of the read-out at that dose, not a potency): 20.7%
Compound 4: the middle estimate sits 5.3 percentage points above what was measured; low and high end bracket the measured number.
By their numbers in this assay, from the lowest: compounds 4, 3, 1 and 2 (each within the scatter of the next).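

In this assay the first step read at this position, 1-methyl-1H-pyrrol-2-yl in place of furan-2-yl on a saturated ring carbon, is a number 4.9 percentage points lower from compound 3 to compound 4 (within the scatter) and so sets no order between the two groups. One five-membered aromatic ring with 1 hetero atom has therefore been exchanged for another without a change that can be told from scatter. Nothing at hand bears on this step. Still open, as far as these compounds go, is how this carbon responds to a group of another kind, such as a phenyl ring, an amine or a carboxylic acid. From the compounds shown here alone, whether the same exchange reads alike on another core also remains open.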